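Methyl for methoxy on the anilide of compound 1

A few compounds are considered here, and "the series" means these few. Any claim that something is new, unique, unknown or untested is made for them only; others in the source may bear on it.

Measured so far in a functional assay on Molt4/C8 cells (Homo sapiens) for cytotoxicity; on this read-out higher numbers stand for weaker inhibition and lower numbers for stronger inhibition:
- compound 1, `COc1ccc(NC(=O)/C=C/C(=O)N2C/C(=C\c3ccc([N+](=O)[O-])cc3)C(=O)/C(=C/c3ccc([N+](=O)[O-])cc3)C2)cc1`: compound 1 gives 940 nM
- compound 2, `Cc1ccc(NC(=O)/C=C/C(=O)N2C/C(=C\c3ccccc3)C(=O)/C(=C/c3ccccc3)C2)cc1C`: compound 2 gives 7900 nM
- compound 3, `O=C(/C=C/C(=O)N1C/C(=C\c2ccccc2)C(=O)/C(=C/c2ccccc2)C1)Nc1ccccc1`: compound 3 gives 520 nM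

Compound 1 stands second highest of the three numbers; its value and that of compound 3 lie within the scatter of each other, while compound 2 sits well above it. Going by the values given here, the only single-point step measured is a 15-fold lower number from compound 2 to compound 3 (1.18 log units; beyond the scatter), which concerns a different pair of groups on the anilide ring and a different core.

Compound 4, `Cc1ccc(NC(=O)/C=C/C(=O)N2C/C(=C\c3ccc([N+](=O)[O-])cc3)C(=O)/C(=C/c3ccc([N+](=O)[O-])cc3)C2)cc1`, differs from compound 1 by methyl in place of methoxy on an aromatic carbon. Among the compounds with values here, no measured pair covers methyl against methoxy on that ring, so the step from compound 2 to compound 3 is only a loose guide; it shows that the anilide substituent can matter, but in that case two methyls were removed rather than one group swapped for another of similar size. A small change in this assay, not beyond the scatter, is therefore expected: a 1.1-fold higher number from compound 1 to compound 4 (0.03 log units; within the scatter). For compound 4 the estimated value is 1000 nM, with a range from 400 nM to 2500 nM.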

Compound 4, half-maximal inhibitory concentration: 700 nM
For compound 4 the middle estimate is 1.4-fold (0.15 log units) above the measured one; measured number inside the range.
By their numbers in this assay, from the lowest: compounds 3, 4 and 1 (each within the scatter of the next); then compound 2.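

In this assay, the change of methoxy to methyl on an aromatic carbon para to a large group gives a 1.3-fold lower number from compound 1 to compound 4 (0.13 log units; within the scatter), the first direct read on this position. On the core shared by compound 1 and compound 4, the position takes either group, and removing the oxygen with its hydrogen-bond acceptor leaves the read-out within the scatter, unlike a 15-fold lower number from compound 2 to compound 3 (1.18 log units; beyond the scatter), which is beyond the scatter but involves other groups on another core. Nothing available explains why methyl and methoxy read alike here.

On these data alone, whether a carboxylic acid, a dimethylamino group or a longer chain such as butoxy at this place would also stay within the scatter remains open. Going by these compounds alone, also open is whether methyl and methoxy read alike on the core of compound 3, and no single-place pair yet isolates the 4-nitrophenyl groups.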